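This account rests on a few compounds, and the source may have more. Where it says the series, first, only, none or still open, it means among the compounds named here.

Measured so far in a functional assay on the whole organism for inhibition, with Mus musculus as the target; a lower number here means that less compound is needed, a higher number that more compound is needed for the effect:

- compound 1 `CCNC(=O)Nc1cccc2c1CN(C)CC2c1ccccc1`: 80 mg/kg
- compound 2 `CCCCNC(=O)Nc1cccc2c1CN(C)CC2c1ccccc1`: about 40 mg/kg

These two compounds share the same core and differ only in the length of one chain. On these numbers, compound 2 stands level with compound 1. Among the compounds with values here, the only measured step is a 2.0-fold lower number from compound 1 to compound 2 (0.30 log units; within the scatter), so the two cannot be told apart.

Compound 3 `CCCCOC(=O)Nc1cccc2c1CN(C)CC2c1ccccc1` has not yet been measured. It keeps the core of compound 2 and makes a single change: butoxy in place of butylamino on a carbonyl carbon. In short, it has butoxy in place of butylamino on a carbonyl carbon.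

Within the data shown here, the step to compound 2, a 2.0-fold lower number from compound 1 to compound 2 (0.30 log units; within the scatter), is the only measured guide, and it bears on this change only loosely. It concerns ethyl in place of hydrogen on a saturated chain carbon, not a change on the carbonyl carbon. Among the measured compounds shown here, no measured pair shows the new exchange, so the data give no direction for it. No step beyond the scatter is therefore expected in this assay.

The estimated change is no change at the digits printed from compound 2 to compound 3 (within the scatter). For compound 3 the expected value is 40 mg/kg, with an estimated range from 15 mg/kg to 110 mg/kg.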

Compound 3, dose for half-maximal effect: 4 mg/kg
Beside the measured number, compound 3's estimate is 10-fold (1.00 log units) above it; measured number outside the range, below it.
By their numbers in this assay, from the lowest: compound 3; then compounds 2 and 1 (each within the scatter of the next).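

Within the data shown here, on the carbonyl carbon, the atom that joins the butyl chain matters far more in this assay than the earlier chain change suggested: butoxy in place of butylamino gives the first clear step (a 10-fold lower number from compound 2 to compound 3 (1.00 log units; beyond the scatter)). The same comparison made from the shorter chain, butoxy in place of ethylamino, gives a larger step (a 20-fold lower number from compound 1 to compound 3 (1.30 log units; beyond the scatter)), although that exchange alters the chain as well as the joining atom. Counted from the two structures, the exchange from butylamino to butoxy removes a hydrogen-bond donor and adds a hydrogen-bond acceptor, but nothing measured here explains why the number falls.

The compounds shown leave open whether this gain belongs to butoxy alone or also holds for other groups joined through oxygen, such as ethoxy or a longer chain. They also cannot separate losing the donor from gaining the acceptor, a question that a plain pentyl chain on the carbonyl carbon, carrying neither, could begin to answer.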